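Swapping Trifluoromethyl for Methyl on a Urea Aryl Ring

This account rests on a few compounds, and the source may have more. Where it says the series, first, only, none or still open, it means among the compounds named here.

Of the compounds shown here, three built on one shared core have been tested in a functional assay on T-24 cells (Homo sapiens) for antiproliferative activity, read by MTT assay, with a stated time of 48 h; on this read-out higher numbers stand for weaker inhibition and lower numbers for stronger inhibition. Compound 1 `Cc1ccc(NC(=O)Nc2cccc(CNc3nccnc3Cl)c2)cc1C` gives 8930 nM. Compound 2 `CN(C)c1ccc(NC(=O)Nc2cccc(CNc3nccnc3Cl)c2)cc1` gives 20200 nM. Compound 3 `O=C(Nc1cccc(CNc2nccnc2Cl)c1)Nc1cccc(C(F)(F)F)c1` gives 5080 nM, the lowest of the three numbers; its gap to compound 1 lies within the usual scatter, while compound 2 stands further off, beyond the scatter.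

Among the compounds with values here, only one single-change step has been measured, a 2.3-fold higher number from compound 1 to compound 2 (0.35 log units; beyond the scatter), and it shows that exchanging one aryl group for another on the urea nitrogen moved the number only modestly.

Compound 4 `Cc1cccc(NC(=O)Nc2cccc(CNc3nccnc3Cl)c2)c1` has not yet been measured. It differs from compound 3 in one place: methyl in place of trifluoromethyl on an aromatic carbon. Within the data shown here, no measured step covers this exact exchange. The closest guide is compound 1, which also carries methyl groups on that ring and sits within the scatter of compound 3. A small step is therefore expected in this assay, most likely toward a slightly higher number, a 1.5-fold higher number from compound 3 to compound 4 (0.17 log units; within the scatter). Compound 4 is estimated at 7500 nM, within a range from 3000 nM to 19000 nM.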

Compound 4, half-maximal inhibitory concentration: 9570 nM
Compound 4: the middle estimate sits 1.3-fold (0.11 log units) below what was measured; measured number inside the range.
By their numbers in this assay, from the lowest: compounds 3, 1 and 4 (each within the scatter of the next); then compound 2.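

In this assay, the first direct test of this exchange shows that methyl in place of trifluoromethyl on this aromatic carbon leaves the number within the usual scatter (a 1.9-fold higher number from compound 3 to compound 4 (0.28 log units; within the scatter)). The same holds for hydrogen in place of the extra methyl on this ring (a 1.1-fold higher number from compound 1 to compound 4 (0.03 log units; within the scatter)), whereas 3-methylphenyl in place of 4-(dimethylamino)phenyl gives a modest change beyond the scatter (a 2.1-fold lower number from compound 2 to compound 4 (0.32 log units; beyond the scatter)). Among these compounds, then, only the step from compound 2 stands clear of the scatter, and the data shown offer no explanation for any of these steps.

Going by these compounds, it remains open whether a carboxylic acid or a nitrile on this same aromatic carbon would also stay within the scatter. Changes to the rest of the shared core are also left open.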